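A few compounds are considered here, and "the series" means these few. Any claim that something is new, unique, unknown or untested is made for them only; others in the source may bear on it.

In a functional assay on MKN-45 cells (Homo sapiens) for inhibition, with a stated time of 72 h (a lower number here means a stronger inhibitor, a higher number a weaker inhibitor), compound 3 (`COc1ccc(S(=O)(=O)N2CCc3cccc(-c4cccc(F)c4)c32)cc1`) gives 84.7 nM, compound 1 (`COc1ccc(S(=O)(=O)N2CCc3cccc(-c4ccc(F)nc4)c32)cc1`) gives 145 nM and compound 2 (`COc1ccc(-c2cccc3c2N(S(=O)(=O)c2ccc(OC)cc2)CC3)cc1`) gives 211 nM. Compound 3 holds the lowest number of the three, but only one of its two gaps is clear: a 1.7-fold lower number from compound 1 to compound 3 (0.23 log units; within the scatter), and a 2.5-fold lower number from compound 2 to compound 3 (0.40 log units; beyond the scatter). Compound 4 (`COc1ccc(S(=O)(=O)N2CCc3cccc(-c4ccc(O)cc4)c32)cc1`) has 4-hydroxyphenyl in place of 3-fluorophenyl on an aromatic carbon. Going by the values given here, no measured compound carries this group. The closest measured group is the 4-methoxyphenyl of compound 2, so the step of a 2.5-fold lower number from compound 2 to compound 3 (0.40 log units; beyond the scatter) bears most, read in reverse, and a 1.5-fold higher number from compound 1 to compound 2 (0.16 log units; within the scatter) adds little. A step of similar size towards a higher number is therefore expected in this assay. The expected step is a 2.1-fold higher number from compound 3 to compound 4 (0.33 log units; beyond the scatter). For compound 4 the estimated value is 180 nM, with an expected range of 70 nM to 420 nM.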

Compound 4, half-maximal inhibitory concentration: 82.6 nM
For compound 4 the middle estimate is 2.2-fold (0.34 log units) above the measured one; the measured number falls inside the stated range.
By their numbers in this assay, from the lowest: compounds 4, 3, 1 and 2 (each within the scatter of the next, the first and the last beyond it).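

In this assay, going by these compounds alone, the one step that changes only the group on the oxygen of the 4-methoxyphenyl, hydrogen in place of methyl, gives a 2.6-fold lower number from compound 2 to compound 4 (0.41 log units; beyond the scatter) and so separates compound 4 from compound 2. The 4-hydroxyphenyl cannot be told apart from the 3-fluorophenyl (a 1.0-fold lower number from compound 3 to compound 4 (0.01 log units; within the scatter)) or from the 6-fluoropyridin-3-yl (a 1.8-fold lower number from compound 1 to compound 4 (0.24 log units; within the scatter)). This aromatic carbon therefore carries a ring with a hydrogen-bond donor without a clear rise in the number. Going by these compounds, whether an amine or a carboxylic acid in place of the hydroxyl would hold this level stays open. No measurement on hand bears on why the steps fall as they do.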